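The compounds below may be only part of what the source reports. "The series", "measured", "known", "first", "only" and "open" are said of these compounds alone.

Measured in an ADME assay on microsomes (Homo sapiens) for metabolic stability; a lower number here means slower removal, a higher number faster removal of the compound:
Compound 1 `Cc1cc(C(F)(F)F)c2cccc(OCc3c(Cl)ccc(S(=O)(=O)N4CCCC4)c3Cl)c2n1`: 233 mL/min/kg
Compound 2 `CNC(=O)[C@@H]1CCCN1S(=O)(=O)c1ccc(Cl)c(COc2cccc3c(-c4cncn4C)cc(C)nc23)c1Cl`: 33.3 mL/min/kg

Of these two, compound 2 has the lower number, and the gap up to compound 1 lies beyond the scatter. The two differ in more than one place, so that gap cannot be tied to any single change. Compound 3 `CNC(=O)[C@@H]1CCCN1S(=O)(=O)c1ccc(Cl)c(COc2cccc3c(-c4cccnc4)cc(C)nc23)c1Cl` keeps the rest of compound 2 and alters one group: pyridin-3-yl in place of 1-methyl-1H-imidazol-5-yl on an aromatic carbon. Here pyridin-3-yl stands in place of 1-methyl-1H-imidazol-5-yl on an aromatic carbon, opposite the ring nitrogen. Going by the values given here, no measured pair shows this exchange, so any forecast in this assay is uncertain. A modest rise in clearance is expected, near the edge of the scatter, and the estimated step is a 1.5-fold higher number from compound 2 to compound 3 (0.18 log units; within the scatter). Compound 3 is expected at 50 mL/min/kg, with a range from 25 mL/min/kg to 105 mL/min/kg.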

Compound 3, clearance: 233 mL/min/kg
The estimate for compound 3 lay 4.7-fold (0.67 log units) below the measured number; measured number outside the range, above it.
By their numbers in this assay, from the lowest: compound 2; then compounds 1 and 3 (each within the scatter of the next).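

With pyridin-3-yl in place of 1-methyl-1H-imidazol-5-yl on this aromatic carbon, opposite the ring nitrogen, this assay gives a 7.0-fold higher number from compound 2 to compound 3 (0.84 log units; beyond the scatter). The step lies beyond the scatter, so with the rest of compound 2 held fixed, the choice of aromatic ring at this position clearly matters for clearance, which the earlier pair, differing in more than one place, could not show. Nothing measured here accounts for the size of this step.

The compounds shown leave open whether the lower number of compound 2 depends on the methyl group of its ring or on the five-membered ring itself. They also leave open where an unmethylated imidazol-5-yl, a pyridin-4-yl or a morpholine on this carbon would fall.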